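From compound 1 to compound 4: trifluoromethyl leaves

A few compounds are considered here, and "the series" means these few. Any claim that something is new, unique, unknown or untested is made for them only; others in the source may bear on it.

Among the measured compounds shown here, in a physicochemical assay for solubility (a lower number here means a less soluble compound, a higher number a more soluble compound), compound 1 (`C[C@H](Oc1ccc(S(C)(=O)=O)cc1C(=O)N1Cc2ccc(C(F)(F)F)cc2C1)C(F)(F)F`) gives 1 ug/mL as the lowest of the three numbers so far. Compound 2 (`COc1ccc2c(c1)CN(C(=O)c1cc(S(C)(=O)=O)ccc1O[C@@H](C)C(F)(F)F)C2`) gives 46 ug/mL and compound 3 (`COc1cccc2c1CN(C(=O)c1cc(S(C)(=O)=O)ccc1O[C@@H](C)C(F)(F)F)C2`) gives 85 ug/mL with both lying beyond the scatter from compound 1. Compound 4 (`C[C@H](Oc1ccc(S(C)(=O)=O)cc1C(=O)N1Cc2ccc(C3CCOCC3)cc2C1)C(F)(F)F`) is still unmeasured and keeps the core of compound 1 with one change, oxan-4-yl in place of trifluoromethyl on an aromatic carbon. For the measured compounds named here, one measured step bears on it: a 46-fold higher number from compound 1 to compound 2 (1.66 log units; beyond the scatter) is large and also removes trifluoromethyl from an aromatic carbon, with methoxy entering. Going by the values given here, compound 3 differs from compound 1 in more than one place and offers no single step. Oxan-4-yl is not methoxy and one step sets no pattern, so the value of compound 2 at 46 ug/mL serves only as a guide, and a smaller step in the same direction is expected, still beyond the scatter. The expected step is a 15-fold higher number from compound 1 to compound 4 (1.18 log units; beyond the scatter) toward a higher number. For compound 4 the estimate is 15 ug/mL with an expected range from 3 ug/mL to 60 ug/mL for this change.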

Compound 4, solubility: 76 ug/mL
Estimate against measurement, compound 4: 5.1-fold (0.70 log units) below; measured number outside the range, above it.
By their numbers in this assay, from the lowest: compound 1; then compounds 2, 4 and 3 (each within the scatter of the next).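

In this assay, oxan-4-yl in place of trifluoromethyl on this aromatic carbon gives a 76-fold higher number from compound 1 to compound 4 (1.88 log units; beyond the scatter), so the large step seen earlier with methoxy is no longer confined to a single entering group. A group carrying a six-membered non-aromatic ring is accepted here, and oxan-4-yl in place of methoxy gives a 1.7-fold higher number from compound 2 to compound 4 (0.22 log units; within the scatter), which leaves compound 2 and compound 4 indistinguishable in this read-out. The compounds shown offer no measurement that accounts for these steps.

On these data alone, both entering groups contain an oxygen, so it remains open whether a carbon-only group such as cyclohexyl or methyl would reach the same level. Also open, as far as these compounds go, is how an amine such as piperidin-4-yl or a carboxylic acid would read on this same aromatic carbon.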